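The source may report more compounds than this note shows. Statements on the series, on what has been measured and on what is new or still open speak of the compounds shown alone.

The measured compounds:
compound 1, `CCS(=O)(=O)Nc1ccc(Oc2ccc(C(F)(F)F)cc2)c(-c2cn(C)c(=O)c3[nH]ccc23)c1`: 583 mL/min/kg
compound 2, `Cn1cc(-c2cc(NS(C)(=O)=O)ccc2Oc2ccccc2C(F)(F)F)c2cc[nH]c2c1=O`: 250 mL/min/kg

Both compounds share one core and were tested in an ADME assay on microsomes from liver (Rattus norvegicus) for metabolic stability, read by HPLC, using NADPH, with stated times of 5 min and 60 min, tested at 10 uM; a higher number here means faster removal of the compound, a lower number slower removal. In this assay compound 1 gives 583 mL/min/kg, the higher of the two numbers. Compound 2 gives 250 mL/min/kg, and the gap between compound 2 and compound 1 lies beyond the usual scatter of the assay, so compound 1 stands as the more rapidly cleared of the pair.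

Compound 3, `CCS(=O)(=O)Nc1ccc(OC2CCN(C)CC2)c(-c2cn(C)c(=O)c3[nH]ccc23)c1`, has not yet been measured in this assay. It keeps the core of compound 1 and differs from it in a single place:
1-methylpiperidin-4-yl in place of 4-(trifluoromethyl)phenyl on an oxygen on an aromatic ring
Among the measured compounds shown here, no step between two measured compounds reproduces this exchange of 1-methylpiperidin-4-yl for 4-(trifluoromethyl)phenyl on the oxygen, so the expectation rests on compound 1 alone and on the size of the change. Compound 3 is expected to show a step of a 2.9-fold lower number from compound 1 to compound 3 (0.46 log units; beyond the scatter) in this assay, a fall that reaches beyond the scatter. Compound 3 is therefore estimated at about 200 mL/min/kg, within a range from 60 mL/min/kg to 500 mL/min/kg.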

Compound 3, clearance: 80 mL/min/kg
Compound 3: middle estimate off by 2.5-fold (0.40 log units), on the high side; the measured number falls inside the stated range.
By their numbers in this assay, from the lowest: compound 3; then compound 2; then compound 1.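

In this assay, placing 1-methylpiperidin-4-yl instead of 4-(trifluoromethyl)phenyl on the oxygen gives a 7.3-fold lower number from compound 1 to compound 3 (0.86 log units; beyond the scatter), a change beyond the scatter. Compound 1 and compound 2 differ in more than one place, so they could not isolate this position, whereas this pair shows that the group on this oxygen alone, with the rest of compound 1 unchanged, can move the clearance by this much. No measurement shown here speaks to what lies behind the step.

Going by these compounds, the exchange removes the trifluoromethyl, replaces an aromatic ring with a non-aromatic one and introduces a ring nitrogen all at once, so the part each of these plays remains open; a cyclohexyl group, a piperidin-4-yl group without the methyl on its nitrogen, or a tetrahydropyran-4-yl group on the same oxygen would help to separate them. On these data alone, it also remains open whether a step of this size would recur on a compound that carries a methyl instead of an ethyl on the sulfonyl group.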